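Thiophene to Ethyl on the Shared Core: An Expected Loss

The compounds below may be only part of what the source reports. "The series", "measured", "known", "first", "only" and "open" are said of these compounds alone.

Measured so far in an assay on isolated protein for inhibition of proto-oncogene tyrosine-protein kinase receptor Ret (Homo sapiens), read by radiometric assay and 33P incorporation, in the presence of a further agent that is not named here; on this read-out higher numbers stand for weaker inhibition and lower numbers for stronger inhibition:
Compound 1 `CC(C)n1nc(-c2cc(-c3cccnc3)on2)c(C(N)=O)c1N` gives 3400 nM.
Compound 2 `CC(C)n1nc(-c2cc(-c3cccs3)on2)c(C(N)=O)c1N` gives 78 nM.

For the measured compounds named here, compound 2 holds the lowest of the two numbers; the single measured step, a 44-fold lower number from compound 1 to compound 2 (1.64 log units; beyond the scatter), separates it from compound 1. Compound 3 `CCc1cc(-c2nn(C(C)C)c(N)c2C(N)=O)no1` differs from compound 2 in one place: ethyl in place of thiophen-2-yl on an aromatic carbon. Going by the values given here, that measured step shows the group in this place matters strongly, but it swaps one ring for another; no measured step removes the ring entirely. For compound 3 the number in this assay is therefore expected to rise, by about a 5.1-fold higher number from compound 2 to compound 3 (0.71 log units; beyond the scatter), with wide uncertainty. The estimate for compound 3 is 400 nM, between 80 nM and 2500 nM.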

Compound 3, half-maximal inhibitory concentration: 631 nM
The estimate for compound 3 lay 1.6-fold (0.20 log units) below the measured number, within the range that was stated.
By their numbers in this assay, from the lowest: compound 2; then compound 3; then compound 1.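

Removing the ring from this place does not abolish inhibition in this assay: ethyl costs ground against thiophen-2-yl (an 8.1-fold higher number from compound 2 to compound 3 (0.91 log units; beyond the scatter)) but still beats pyridin-3-yl (a 5.4-fold lower number from compound 1 to compound 3 (0.73 log units; beyond the scatter)). A ring here is therefore neither needed for a number below that of compound 1 nor enough by itself for a low number, since the identity of the group decides the outcome. No evidence here explains this order.

Open, from the compounds shown here alone, is whether a longer chain such as butyl, or an amine, would land nearer compound 2 or compound 1.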